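Ring-bearing tails on the amide nitrogen of the shared core

This account rests on a few compounds, and the source may have more. Where it says the series, first, only, none or still open, it means among the compounds named here.

Measured so far in a functional assay on PC-3 cells (Homo sapiens) for inhibition, with a stated time of 72 h; on this read-out lower numbers stand for stronger inhibition and higher numbers for weaker inhibition:
- compound 1, `Cc1nc(-c2nc[nH]n2)ccc1-c1cnc2c(n1)N(CCC1CCOCC1)C(=O)CN2`: 34 nM
- compound 2, `Cc1nc(-c2nc[nH]n2)ccc1-c1cnc2c(n1)N([C@H]1CC[C@@H](O)CC1)C(=O)CN2`: 37 nM
- compound 3, `COCCN1C(=O)CNc2ncc(-c3ccc(-c4nc[nH]n4)nc3C)nc21`: 137 nM

Compound 3 stands highest of the three numbers; the two ring-bearing tails lie below it by a 4.0-fold higher number from compound 1 to compound 3 (0.61 log units; beyond the scatter) and a 3.7-fold higher number from compound 2 to compound 3 (0.57 log units; beyond the scatter), both beyond the scatter, while compounds 1 and 2 sit within the scatter of each other (a 1.1-fold higher number from compound 1 to compound 2 (0.04 log units; within the scatter)).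

Compound 4, `CO[C@H]1CC[C@@H](CN2C(=O)CNc3ncc(-c4ccc(-c5nc[nH]n5)nc4C)nc32)CC1`, differs from compound 3 by 4-methoxycyclohexyl in place of methoxymethyl on a saturated chain carbon bound to an amide-type nitrogen in a ring. The change brings back a six-membered saturated ring on the tail, as in compound 2, so the steps from compound 3 to compounds 1 and 2 are the ones that bear on it. On that basis a drop of about the same size is expected, and compound 4 is estimated at 50 nM (range 20 nM to 140 nM), a step of a 2.7-fold lower number from compound 3 to compound 4 (0.44 log units; beyond the scatter).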

Compound 4, half-maximal inhibitory concentration: 24 nM
Compound 4: the middle estimate sits 2.1-fold (0.32 log units) above what was measured; low and high end bracket the measured number.
By their numbers in this assay, from the lowest: compounds 4, 1 and 2 (each within the scatter of the next); then compound 3.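

In this assay, the 4-methoxycyclohexyl tail gives a 5.7-fold lower number from compound 3 to compound 4 (0.76 log units; beyond the scatter), so a six-membered ring of carbon only also serves at this position. The step to this tail reads a 1.5-fold lower number from compound 2 to compound 4 (0.19 log units; within the scatter) and a 1.4-fold lower number from compound 1 to compound 4 (0.15 log units; within the scatter): the three ring-bearing tails differ in hydroxyl, methoxy or ring oxygen and in how far the ring stands from the amide-type nitrogen, yet neither step goes beyond the scatter. No measurement shown gives a reason for these steps.

Open, on these data alone, is whether an amine or a carboxylic acid on the cyclohexyl ring would hold the number at this level. Also open, as far as these compounds go, is how the other stereoisomer of the 4-methoxycyclohexyl tail would read.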